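The source may report more compounds than this note shows. Statements on the series, on what has been measured and on what is new or still open speak of the compounds shown alone.

Measured compounds:
compound 1 `COC(=O)c1ccc(NCc2cncn2Cc2ccc(C#N)cc2)cc1-c1ccccc1` — > 10000 nM
compound 2 `COC(=O)c1ccc(NCc2cncn2Cc2ccc(C(C)(C)C)cc2)cc1-c1ccccc1` — "not determined" (no result reported)

In a toxicity assay on NIH3T3 cells (Mus musculus) for cytotoxicity, read by resazurin assay (on this read-out higher numbers stand for an effect only at larger amounts of compound and lower numbers for an effect already at smaller amounts), compound 1 gives only a limit, > 10000 nM. Compound 2 stands nowhere on the numbers shown, since in this assay it has no result. Within the data shown here, the one value shown sits at the limit of > 10000 nM in this assay, at which 1 of the 2 values shown sits.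

Compound 3 `COC(=O)c1ccc(NCc2cncn2Cc2ccccc2C#N)cc1-c1ccccc1` differs from compound 2 by 2-cyanophenyl in place of 4-(tert-butyl)phenyl on a saturated chain carbon bound to an aromatic nitrogen. Among the measured compounds shown here, no step between measured compounds exists in this assay, so the size of the step is open; with compound 1 at a limit, no shift beyond the scatter is expected. Compound 3 is estimated at 10000 nM, expected between 3000 nM and 30000 nM.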

Compound 3, half-maximal effective concentration: 25000 nM
Estimate against measurement, compound 3: 2.5-fold (0.40 log units) below, within the range that was stated.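

No step can be read from compound 1 to compound 3, since compound 1 gives only a limit: the limit of > 10000 nM in this assay, at which 1 of the 3 values shown sits.
The compounds shown leave open whether 2-cyanophenyl in place of 4-cyanophenyl shifts the read-out at all.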